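The compounds below may be only part of what the source reports. "The series", "measured", "known", "first", "only" and "open" are said of these compounds alone.

Compound 2 `N#Cc1ccc(/C=N/NC(=O)Nc2cc3c(Nc4ccc(F)c(Cl)c4)ncnc3cc2O[C@H]2CCOC2)cc1` sits highest of the two numbers in a functional assay on A549 cells (Homo sapiens) for cytotoxicity, read by MTT assay, with a stated time of 72 h (a higher number here means a weaker inhibitor, a lower number a stronger inhibitor), with 29100 nM. Going by the values given here, its nearest neighbour, compound 1 `O=C(N/N=C/c1cccc(Br)c1)Nc1cc2c(Nc3ccc(F)c(Cl)c3)ncnc2cc1O[C@H]1CCOC1`, gives 10700 nM in this assay, and the single measured step, a 2.7-fold higher number from compound 1 to compound 2 (0.43 log units; beyond the scatter), is the only comparison available. Among the compounds with values here, compound 3 `O=C(N/N=C/c1cc(Br)c(O)c(Br)c1)Nc1cc2c(Nc3ccc(F)c(Cl)c3)ncnc2cc1O[C@H]1CCOC1` has not yet been measured in this assay. 3,5-dibromo-4-hydroxyphenyl in place of 4-cyanophenyl on a carbon with a double bond to nitrogen The change bears directly on the measured step: the entering group, like the 3-bromophenyl of compound 1, carries bromine on the ring in place of the nitrile, while also adding a hydroxyl whose effect no measured pair shows. Since the step from compound 1 to compound 2 was modest, a step of comparable size back toward a lower number is expected, with wide uncertainty for the unknown hydroxyl. For compound 3 the expected step in this assay is a 2.4-fold lower number from compound 2 to compound 3 (0.38 log units; beyond the scatter). Compound 3 is estimated at 12000 nM, within 4000 nM to 36000 nM.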

Compound 3, half-maximal inhibitory concentration: 8910 nM
Compound 3: the middle estimate sits 1.3-fold (0.13 log units) above what was measured; the range from low to high includes it.
By their numbers in this assay, from the lowest: compounds 3 and 1 (each within the scatter of the next); then compound 2.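

In this assay, 3,5-dibromo-4-hydroxyphenyl in place of 4-cyanophenyl on the carbon with a double bond to nitrogen gives a 3.3-fold lower number from compound 2 to compound 3 (0.51 log units; beyond the scatter) and so sets compound 2, the only nitrile in the series, apart from both bromine-bearing compounds. Compound 1 and compound 3 are not separated, with a 1.2-fold lower number from compound 1 to compound 3 (0.08 log units; within the scatter) between them, so at this position 3,5-dibromo-4-hydroxyphenyl and 3-bromophenyl cannot be told apart in this read-out. No measurement available here accounts for these differences.

The compounds shown leave open how much of the step from the nitrile comes from the hydroxyl and how much from the bromines, as no pair separates them. They also leave open how an amine or a carboxylic acid on this ring would read in this assay at this position.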